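A few compounds are considered here, and "the series" means these few. Any claim that something is new, unique, unknown or untested is made for them only; others in the source may bear on it.

Working notes on the series of the shared core, with the ester group varied.

Compound 1 `O=C(OCC(F)(F)F)c1ccsc1NC(=O)[C@@H]1CCCN1` carries a 2,2,2-trifluoroethyl ester. In a toxicity assay on HUVEC cells (Homo sapiens) for inhibition (a higher number here means a weaker inhibitor of growth, a lower number a stronger inhibitor of growth), compound 1 gives > 250 ug/mL, which is a limit of the assay and not a number. Compound 2 `O=C(OC1CCCCC1)c1ccsc1NC(=O)[C@@H]1CCCN1` carries a cyclohexyl ester; in this assay compound 2 gives 137 ug/mL. Compound 3 `CCOC(=O)c1ccsc1NC(=O)[C@@H]1CCCN1` carries an ethyl ester. In this assay compound 3 gives > 250 ug/mL, again a limit of the assay. Among the compounds with values here, compound 3 thus stands at the limit, alongside compound 1, and the only numerical reading in the set belongs to compound 2 (the limit of > 250 ug/mL in this assay, at which 2 of the 3 values shown sit).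

The measured steps are an at least 1.8-fold lower number from compound 1 to compound 2 (0.26 log units; that floor lies within the scatter), an at least 1.8-fold higher number from compound 2 to compound 3 (0.26 log units; that floor lies within the scatter) and a step that the two limits leave unreadable from compound 1 to compound 3. The two that can be read point the same way for smaller esters.

Compound 4 `COC(=O)c1ccsc1NC(=O)[C@@H]1CCCN1` is the methyl ester. Its change from compound 3 is hydrogen in place of methyl on a saturated chain carbon bound to an oxygen next to a carbonyl group.

This is the smallest step in the set, smaller than the shift from cyclohexyl to ethyl. Compound 4 is therefore expected to remain at the limit, with a step that the limit leaves unreadable from compound 3 to compound 4 expected to be no step beyond the scatter. The estimate for compound 4 is 350 ug/mL, within 180 ug/mL to 700 ug/mL.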

Compound 4, concentration for 50% growth inhibition: > 250 ug/mL
Compound 4: a limit, no number (the forecaster's own chance of this, stated with the estimate: 80%); the middle value lies beyond the limit too.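

In this assay compound 4 gives > 250 ug/mL, which is a limit of the assay and not a number. Going from ethoxycarbonyl to methoxycarbonyl therefore yields no reading: the steps among compound 1, compound 3 and compound 4 cannot be read, and the only readable new step is an at least 1.8-fold higher number from compound 2 to compound 4 (0.26 log units; that floor lies within the scatter). The cyclohexyl ester of compound 2 remains the only ester with a numerical reading, and the methyl ester adds to the compounds at the limit: the limit of > 250 ug/mL in this assay, at which 3 of the 4 values shown sit.

On these data alone, whether the esters at the limit differ from one another stays open, since the limit hides any such difference. Also open, as far as these compounds go, is how a longer chain such as a butyl ester, or a carboxylic acid in place of the ester, would read in this assay.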